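Working notes on an amide-linked series, compounds 1 to 4

The source may report more compounds than this note shows. Statements on the series, on what has been measured and on what is new or still open speak of the compounds shown alone.

In a functional assay on a cell-free system (plasma, Oryctolagus cuniculus) for inhibition of platelet-activating factor acetylhydrolase (Homo sapiens), tested at 100 nM (on this read-out lower numbers stand for less inhibition and higher numbers for more inhibition at the one concentration tested (going by the name of the read-out)), compound 1 `CCCCCCCCN(C)C(=O)Cn1cc(Cc2cnc(OCc3ccccc3)nc2)c(=O)nc1SCc1ccc(F)cc1` gives 8%.
In this assay compound 2 `CCCCCCCCN(C)C(=O)Cn1cc(Cc2cnc(=O)n(C)c2)c(=O)nc1SCc1ccc(F)cc1` gives 19%.
In this assay compound 3 `CCCCCCCCCCCCN(C)C(=O)Cn1cc(Cc2cnc(=O)n(C)c2)c(=O)nc1SCc1ccc(F)cc1` gives 32%.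

Compound 3 stands highest of the three in this assay; the nearest is compound 2, with a number 13 percentage points higher from compound 2 to compound 3 (beyond the scatter), and compound 1 lies lowest. Compound 4 `CCCCCCCCCCCCN(C)C(=O)Cn1cc(Cc2cnc(=O)n(CC(=O)NCCO)c2)c(=O)nc1SCc1ccc(F)cc1` differs from compound 3 by (2-hydroxyethyl)carbamoyl in place of hydrogen on a saturated chain carbon bound to an aromatic nitrogen. Within the data shown here, the only measured step, a number 13 percentage points higher from compound 2 to compound 3 (beyond the scatter), concerns the alkyl chain and not this position, so no measured step bears on the change. The expectation for compound 4 is therefore a step of a number 2 percentage points lower from compound 3 to compound 4 (within the scatter), none beyond the scatter. Compound 4 is estimated at 30%, in the range 10% to 55%.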

Compound 4, a percentage reported as inhibition, at one concentration (the size of the read-out at that concentration, not a potency): 37%
For compound 4 the middle estimate is 7 percentage points below the measured one; measured number inside the range.
By their numbers in this assay, from the lowest: compound 1; then compound 2; then compounds 3 and 4 (each within the scatter of the next).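

Among these compounds, the position on the saturated chain carbon bound to an aromatic nitrogen had no measured step before, and it now has one: (2-hydroxyethyl)carbamoyl in place of hydrogen gives a number 5 percentage points higher from compound 3 to compound 4 (within the scatter) in this assay. This sizeable uncharged group therefore leaves the read-out unresolved from that of the parent, so the position accepts the change without a detectable loss. No supporting data bear on why this is so.

On these data alone, whether a carboxylic acid or an amine at the end of this group would read the same remains open. So does whether the change carries over to compound 2.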